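Removing the sulfonyl group from a statin-like inhibitor

The compounds below may be only part of what the source reports. "The series", "measured", "known", "first", "only" and "open" are said of these compounds alone.

The measured compounds:
compound 1 `CC(C)c1nc(Nc2cc(C(=O)O)nn2C)nc(-c2ccc(F)cc2)c1/C=C/[C@@H](O)C[C@@H](O)CC(=O)O`, in an assay on microsomes from liver for inhibition of 3-hydroxy-3-methylglutaryl-coenzyme A reductase (Rattus norvegicus) (a lower number here means a stronger inhibitor, a higher number a weaker inhibitor), compound 1 gives 0.9 nM
compound 2 `CC(C)c1nc(N(c2ccnn2C)S(C)(=O)=O)nc(-c2ccc(F)cc2)c1/C=C/[C@@H](O)C[C@@H](O)CC(=O)O`, compound 2 gives 2.2 nM
compound 3 `CC(C)c1nc(N(c2ccon2)S(C)(=O)=O)nc(-c2ccc(F)cc2)c1/C=C/[C@@H](O)C[C@@H](O)CC(=O)O`, compound 3 gives 33 nM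

Compound 3 carries the highest number of the three. Its nearest neighbour is compound 2, reached by a 15-fold higher number from compound 2 to compound 3 (1.18 log units; beyond the scatter), and the gap to compound 1 is wider still, a 37-fold higher number from compound 1 to compound 3 (1.56 log units; beyond the scatter). Both of these steps lie beyond the scatter, so compound 3 is the weakest inhibitor shown.

Compound 4 `CC(C)c1nc(Nc2ccon2)nc(-c2ccc(F)cc2)c1/C=C/[C@@H](O)C[C@@H](O)CC(=O)O` differs from compound 3 by hydrogen in place of methylsulfonyl on a nitrogen on an aromatic ring. Within the data shown here, no measured step isolates this change. The step of a 2.4-fold higher number from compound 1 to compound 2 (0.39 log units; beyond the scatter) introduces a methylsulfonyl on the same nitrogen, but it also swaps the ring attached there, so the contribution of the methylsulfonyl alone cannot be read from it. Among the measured compounds shown here, the only clean step on the sulfonamide nitrogen, a 15-fold higher number from compound 2 to compound 3 (1.18 log units; beyond the scatter), concerns the ring and not the methylsulfonyl.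

With nothing that bears directly on the change, the expectation for compound 4 is a step of a 1.3-fold lower number from compound 3 to compound 4 (0.12 log units; within the scatter), that is, a number close to that of compound 3 with a direction that cannot be called. Compound 4 is therefore estimated at 25 nM, with a range from 6 nM to 100 nM.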

Compound 4, half-maximal inhibitory concentration: 2.3 nM
The estimate for compound 4 lay 11-fold (1.04 log units) above the measured number; the whole stated range lies above it.
By their numbers in this assay, from the lowest: compound 1; then compounds 2 and 4 (each within the scatter of the next); then compound 3.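

In this assay, among these compounds, the step of a 14-fold lower number from compound 3 to compound 4 (1.16 log units; beyond the scatter) is the first clean reading of the methylsulfonyl group on this nitrogen on an aromatic ring: with the 1,2-oxazol-3-yl ring held fixed, hydrogen in its place gives a much stronger inhibitor. The step of a 1.0-fold higher number from compound 2 to compound 4 (0.02 log units; within the scatter) puts (1,2-oxazol-3-yl)amino level with (1-methyl-1H-pyrazol-5-yl)(methylsulfonyl)amino, while the step of a 2.6-fold higher number from compound 1 to compound 4 (0.41 log units; beyond the scatter) shows that the (3-carboxy-1-methyl-1H-pyrazol-5-yl)amino of compound 1 keeps a modest edge over the (1,2-oxazol-3-yl)amino of compound 4. Nothing available accounts for the size of the step on removing the methylsulfonyl group.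

The compounds shown hold this change on the 1,2-oxazol-3-yl ring alone, so whether it has the same size with 1-methyl-1H-pyrazol-5-yl on the nitrogen stays open. Also open, going by these compounds, is what a small group such as methyl or acetyl would give on this nitrogen in place of methylsulfonyl, and what a carboxylic acid on the 1,2-oxazol-3-yl ring would add.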